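A few compounds are considered here, and "the series" means these few. Any claim that something is new, unique, unknown or untested is made for them only; others in the source may bear on it.

Of the compounds shown here, two carry a number so far. Compound 1 `O=S(=O)(NCCCNc1nccc(-c2c(-c3cccc(F)c3)nc3sccn23)n1)c1ccc(Br)cc1` gives 9400 nM in a functional assay on SK-MEL-28 cells (Homo sapiens) for cytotoxicity, read by MTT assay; a lower number here means a stronger inhibitor, a higher number a weaker inhibitor. Compound 2 `O=C(NCCNc1nccc(-c2c(-c3cccc(F)c3)nc3sccn23)n1)c1ccccc1` gives 17000 nM in this assay. Among the measured compounds shown here, the one step that joins them, a 1.8-fold higher number from compound 1 to compound 2 (0.26 log units; within the scatter), stays within the scatter, so compound 2 holds the higher of the two numbers without standing apart from compound 1. Compound 3 `Cc1ccc(C(=O)NCCNc2nccc(-c3c(-c4cccc(F)c4)nc4sccn34)n2)cc1` differs from compound 2 by methyl in place of hydrogen on an aromatic carbon. For the measured compounds named here, no measured step touches the benzamido ring itself; the step from compound 1 to compound 2 swaps the whole group on the chain and says nothing about a methyl on the phenyl of compound 2. With no comparable step shown, the expectation for compound 3 is a number close to that of compound 2. The expected step is therefore a 1.1-fold lower number from compound 2 to compound 3 (0.05 log units; within the scatter), none beyond the scatter. Compound 3 is thus expected at 15000 nM, in the range 6000 nM to 40000 nM.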

Compound 3, half-maximal inhibitory concentration: 18800 nM
Compound 3: the middle estimate sits 1.3-fold (0.10 log units) below what was measured; the measured number falls inside the stated range.
By their numbers in this assay, from the lowest: compounds 1, 2 and 3 (each within the scatter of the next).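

Among the compounds shown here, the step of a 1.1-fold higher number from compound 2 to compound 3 (0.04 log units; within the scatter) is the first reading on the benzamido ring itself: in this assay, methyl in place of hydrogen on the aromatic carbon para to a large group stays within the scatter. The wider swap to ((4-methylphenyl)carbonyl)amino, read as a 2.0-fold higher number from compound 1 to compound 3 (0.30 log units; within the scatter) and printed as within the scatter, adds no separation either, so compound 1, compound 2 and compound 3 cannot be told apart in this assay. No supporting measurement bears on why the methyl step is this small.

On these data alone, whether an amine or a carboxylic acid on the same ring carbon, or a methyl on another carbon of the phenyl, would move the number beyond the scatter stays open. For the compounds shown here, the effect of a longer chain in place of the one in compound 2 is equally open.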